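Alkyne-linked phenoxyacetic acids: chain change at the pyridine substituent

This account rests on a few compounds, and the source may have more. Where it says the series, first, only, none or still open, it means among the compounds named here.

Measured so far:
compound 1 `O=C(O)COc1ccc(Cl)cc1C#Cc1ccc(CO)cc1F`: 28 nM
compound 2 `CC(C)Cc1ccncc1C#Cc1cc(Cl)ccc1OCC(=O)O`: 4.9 nM

Both compounds were run in an assay on CHO cells for displacement of a labelled ligand from prostaglandin D2 receptor 2 (Homo sapiens), read by scintillation counting; on this read-out lower numbers stand for stronger inhibition and higher numbers for weaker inhibition. Compound 2 gives the lower of the two numbers, and the gap between it and compound 1 lies beyond the usual scatter of repeated measurements; compound 1 and compound 2 differ at more than one place, so this gap is not broken down into single changes.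

The next compound, compound 3 `CCCCCCc1ccncc1C#Cc1cc(Cl)ccc1OCC(=O)O`, differs from compound 2 in one place: pentyl in place of isopropyl on a saturated chain carbon bound to an aromatic carbon; the same difference, cut one bond further out, reads isobutyl to hexyl. For the measured compounds named here, no measured pair shows such a chain change, so there is no step to lean on. The branched group is exchanged for a longer straight chain of the same kind of atoms, without any change in ring count, donors, acceptors or charge.

The expected step from compound 2 to compound 3 in this assay is a 1.4-fold higher number from compound 2 to compound 3 (0.15 log units; within the scatter), small and most likely within the scatter, with a slight lean towards a weaker number. For compound 3 the estimated value in this assay is 7 nM, in a range from 2.5 nM to 20 nM.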

Compound 3, inhibition constant: 43 nM
Compound 3: the middle estimate sits 6.1-fold (0.79 log units) below what was measured, outside the stated range (above it).
By their numbers in this assay, from the lowest: compound 2; then compounds 1 and 3 (each within the scatter of the next).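

In this assay, for the compounds shown here, the place on a saturated chain carbon bound to an aromatic carbon proves sensitive to the chain it carries: pentyl in place of isopropyl gives an 8.8-fold higher number from compound 2 to compound 3 (0.94 log units; beyond the scatter) as the first single-place step. The step lies beyond the scatter and points towards weaker inhibition, so exchanging the branched group for a longer straight chain is enough to shift the number, even with ring count, donors, acceptors and net charge unchanged. No measurement at hand accounts for this shift, which therefore stands as an observation on a single pair.

Chain length and branching change together in this pair, so it remains open which of the two carries the step, or whether both contribute. At the same place, a straight propyl chain, a tert-butyl group or a pentyl chain ending in a primary amine would lie outside the compounds shown, and their numbers could help separate length, branching and the nature of the chain end.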